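A few compounds are considered here, and "the series" means these few. Any claim that something is new, unique, unknown or untested is made for them only; others in the source may bear on it.

Two compounds share the core of compound 1 `O=C1O/C(=C\Cn2cc(-c3ccc(Br)cc3)nn2)C(OCc2ccccc2)=C1OCc1ccccc1` and were tested in a functional assay on HepG2 cells (Homo sapiens) for antiproliferative activity, read by MTT assay, with a stated time of 72 h; on this read-out higher numbers stand for weaker inhibition and lower numbers for stronger inhibition. Compound 1 in this assay reaches only the limit > 100000 nM, which is a boundary of the measurement rather than a number; this is the point (the limit of > 100000 nM in this assay, at which 1 of the 2 values shown sits). Within the data shown here, compound 2 `O=C1O[C@H]([C@@H](O)Cn2cc(-c3cccc(O)c3)nn2)C(OCc2ccccc2)=C1OCc1ccccc1` in this assay gives 62700 nM, the only numerical value available. Compound 3 `COc1ccccc1-c1cn(C[C@H](O)[C@H]2OC(=O)C(OCc3ccccc3)=C2OCc2ccccc2)nn1` is not yet measured; it differs from compound 2 by 2-methoxyphenyl in place of 3-hydroxyphenyl on an aromatic carbon, in words 2-methoxyphenyl in place of 3-hydroxyphenyl on an aromatic carbon. Among the measured compounds shown here, no measured pair with a single change exists, so the step can only be anticipated. The estimate for this step is a 1.3-fold higher number from compound 2 to compound 3 (0.11 log units; within the scatter), a shift expected to stay within the scatter or to run slightly toward weaker inhibition. Compound 3 is therefore expected to give about 80000 nM in this assay, within a range from 30000 nM to 200000 nM.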

Compound 3, half-maximal inhibitory concentration: > 100000 nM
Compound 3 gave a limit, no number (the forecaster's own chance of this, stated with the estimate: 35%); middle value at least 1.2-fold (0.09 log units) away from the limit.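

In this assay compound 3 reaches only a limit, > 100000 nM. Among these compounds, this is the first comparison with a single change on this aromatic carbon of the five-membered ring, and it reads an at least 1.5-fold higher number from compound 2 to compound 3 (0.20 log units; that floor lies within the scatter), so 2-methoxyphenyl in place of 3-hydroxyphenyl brings no sign of stronger inhibition, although the floor alone does not establish a weakening and the true size of the step stays unknown. The limit now accounts for most of the compounds shown: the limit of > 100000 nM in this assay, at which 2 of the 3 values shown sit.

The change alters the hydrogen-bond donor count and the heavy atom count together, so this pair cannot tell which of the two matters. Going by these compounds, it also remains open whether an aminophenyl or a carboxyphenyl group on this carbon would give a numerical value in this assay.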